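Chloro in place of fluoro on an aromatic carbon

A few compounds are considered here, and "the series" means these few. Any claim that something is new, unique, unknown or untested is made for them only; others in the source may bear on it.

Of the compounds shown here, two built on a shared core have numbers so far. In a functional assay on Cortical neurone cells (Mus musculus, strain C57BL/6), read by FLIPR and calcium flux, with a stated time of 8 min (a higher number here means a weaker inhibitor, a lower number a stronger inhibitor), compound 1 (`O=c1cc(Cc2ccccc2)[nH]c2nc(Cc3ccc(Cl)cc3)nn12`) gives 4280 nM as its half-maximal inhibitory concentration, and compound 2 (`O=c1cc(-c2ccccc2)[nH]c2nc(Cc3ccc(F)cc3)nn12`) gives 2520 nM on the same read-out. These two numbers lie within the usual scatter of each other, so compound 2 stands level with compound 1. The pair also differs in more than one place, so it isolates no single change.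

Compound 3 (`O=c1cc(-c2ccccc2)[nH]c2nc(Cc3ccc(Cl)cc3)nn12`) has yet to be measured. It departs from compound 2 in one place (chloro in place of fluoro on an aromatic carbon), with chloro in place of fluoro on an aromatic carbon, turning 4-fluorobenzyl into 4-chlorobenzyl. Going by the values given here, no measured pair shows this exchange alone. Compound 1 carries the same 4-chlorobenzyl group and gives 4280 nM in the same range as compound 2, although it differs from compound 3 elsewhere. No step beyond the scatter is therefore expected in this assay. The estimated 1.1-fold higher number from compound 2 to compound 3 (0.05 log units; within the scatter) is small and has no firm direction. For compound 3 the expected value is 2800 nM (estimated range 1200 nM to 6500 nM).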

Compound 3, half-maximal inhibitory concentration: 1830 nM
Estimate against measurement, compound 3: 1.5-fold (0.18 log units) above, within the range that was stated.
By their numbers in this assay, from the lowest: compounds 3, 2 and 1 (each within the scatter of the next, the first and the last beyond it).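

In this assay, going by these compounds alone, the exchange of fluoro for chloro, seen alone here for the first time, gives a 1.4-fold lower number from compound 2 to compound 3 (0.14 log units; within the scatter) and leaves compound 2 and compound 3 level, so at this position 4-chlorobenzyl and 4-fluorobenzyl cannot be told apart. With the 4-chlorobenzyl group held fixed, the other single change, phenyl in place of benzyl, gives a 2.3-fold lower number from compound 1 to compound 3 (0.37 log units; beyond the scatter) and is the only one of the two steps beyond the scatter, though a modest one, so among these compounds the step comes from the phenyl-for-benzyl change and not from the halogen. No measurement is at hand that would explain either step.

The compounds shown carry only these two halogens on the benzyl ring, so it remains open whether a methoxy group, a nitrile or an amine at that position, or a bare hydrogen, would give a number apart from theirs. From the compounds shown here alone, it also remains open how a longer chain, such as phenethyl, would compare with phenyl and benzyl at the other place on the shared core.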